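The source may hold more compounds than are shown below. What is called first, only, known or untested is meant among the compounds shown, and "the series" means these compounds.

Measured compounds:
- compound 1, `CCCCc1ccc(CNC(=O)OC(C)(C)C)c(=O)n1Cc1ccc(-c2ccccc2-c2nn[nH]n2)cc1`: 10 nM
- compound 2, `CCCCc1cccc(=O)n1Cc1ccc(-c2ccccc2-c2nn[nH]n2)cc1`: 4 nM

In a functional assay (aorta) for antagonist activity, with Oryctolagus cuniculus as the target (on this read-out higher numbers stand for weaker inhibition and lower numbers for stronger inhibition), compound 2 stands at the lowest of the two numbers, and its nearest neighbour is compound 1, which gives 10 nM in this assay. Among the compounds with values here, the single step between them, a 2.5-fold lower number from compound 1 to compound 2 (0.40 log units; beyond the scatter), is modest but beyond the scatter, and it comes from a hydrogen in place of ((tert-butoxycarbonyl)amino)methyl on an aromatic carbon.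

Compound 3, `CCCCc1ccc(C)c(=O)n1Cc1ccc(-c2ccccc2-c2nn[nH]n2)cc1`, has not yet been measured in this assay. It differs from compound 2 by methyl in place of hydrogen on an aromatic carbon. Within the data shown here, the only measured step that bears on this position is the one from compound 1 to compound 2, where a large group was removed and the number fell by a modest amount. A methyl is far smaller than that group, so the expected effect lies between the two measured values and most likely within the scatter. Compound 3 is therefore expected to give 5 nM in this assay, within a range of 2 nM to 15 nM, which means an estimated step of a 1.3-fold higher number from compound 2 to compound 3 (0.10 log units; within the scatter).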

Compound 3, half-maximal inhibitory concentration: 7 nM
Beside the measured number, compound 3's estimate is 1.4-fold (0.15 log units) below it; the range from low to high includes it.
By their numbers in this assay, from the lowest: compounds 2, 3 and 1 (each within the scatter of the next, the first and the last beyond it).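

In this assay, a methyl on this aromatic carbon, two atoms from the ring nitrogen, gives a 1.8-fold higher number from compound 2 to compound 3 (0.24 log units; within the scatter), so the smallest carbon group tried here at this position produces no change that can be told from the scatter. Compound 3 also offers a second comparison, a 1.4-fold lower number from compound 1 to compound 3 (0.15 log units; within the scatter), which shows that removing the (tert-butoxycarbonyl)amino group from the methyl carbon likewise produces no readable change, so the difference earlier seen across the whole substituent cannot be assigned to either part of it. No measurement given here offers an explanation for these numbers.

The compounds shown leave open how this position responds to groups of other kinds and sizes between methyl and the full carbamate side chain, such as a free aminomethyl, a carboxylic acid or a longer chain like ethyl or propyl. They also leave open whether a group placed on the neighbouring ring carbons, rather than on this one, would give a step beyond the scatter.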